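The compounds below may be only part of what the source reports. "The series", "measured", "known", "first", "only" and "open" are said of these compounds alone.

Measured so far in a functional assay on SW1573 cells (Homo sapiens) for inhibition, read by sulforhodamine B assay, with a stated time of 48 h; a lower number here means a stronger inhibitor of growth, a higher number a weaker inhibitor of growth:

Compound 1 `CC(C)=CC1C(C(=O)OCC2COCCOCCOCCOCCOCCO2)C1(C)C` gives 54000 nM.
Compound 2 `O=C(CCCCC1CCCCC1)OCC1COCCOCCOCCO1` reaches only the limit of the assay, > 100000 nM.
Compound 3 `O=C(CCCCc1ccccc1)OCC1COCCOCCOCCOCCOCCO1` likewise reaches only the limit of the assay, > 100000 nM.

For the measured compounds named here, compound 1 thus stands as the only compound with a real number; the other two sit at the limit of > 100000 nM in this assay, at which 2 of the 3 values shown sit, so no ordering among them can be read.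

Compound 4 `O=C(CCCCC1CCCCC1)OCC1COCCOCCOCCOCCOCCO1` is the next to be tested. It differs from compound 1 in one place: 4-cyclohexylbutyl in place of 2,2-dimethyl-3-(2-methylprop-1-en-1-yl)cyclopropyl on a carbonyl carbon. Going by the values given here, the one measured step that bears on this change is an at least 1.8-fold higher number from compound 1 to compound 3 (0.26 log units; that floor lies within the scatter), where the ester group on the carbonyl carbon was exchanged and the result went to the limit. Compound 2, which carries the same 4-cyclohexylbutyl group as compound 4 on a smaller core, also gives only a limit. Both pieces of evidence point toward a weaker inhibitor of growth for compound 4, most likely again beyond the reach of the assay.

Compound 4 is therefore expected to give about 150000 nM in this assay, within 60000 nM to 400000 nM, which would be a step of a 2.8-fold higher number from compound 1 to compound 4 (0.44 log units; beyond the scatter).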

Compound 4, concentration for 50% growth inhibition: 51000 nM
The estimate for compound 4 lay 2.9-fold (0.47 log units) above the measured number; measured number outside the range, below it.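

In this assay the step is a 1.1-fold lower number from compound 1 to compound 4 (0.02 log units; within the scatter), so on this carbonyl carbon a long chain ending in a cyclohexyl ring serves as well as the cyclopropyl group of compound 1. Compound 3 gives > 100000 nM, which is a limit of the assay and not a number. Its phenyl ring exchanged for cyclohexyl gives an at least 1.9-fold lower number from compound 3 to compound 4 (0.29 log units; that floor lies within the scatter), so the ring at the end of the chain may matter, but that floor is too small to show it.

Compound 2, with the same 4-cyclohexylbutyl group on a smaller core, gives > 100000 nM, again a limit and not a number, so the effect of core size cannot be sized. As far as these compounds go, whether a longer chain, or a chain ending in an amine or a carboxylic acid, would give a lower number stays open.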